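The source may hold more compounds than are shown below. What is called first, only, known or untested is meant among the compounds shown, and "the series" means these compounds.

Working notes on the series. Compound 1 `O=c1ccc(CO)nn1Cc1ccccc1` carries a hydroxymethyl group on the shared core. In a functional assay on aorta (Rattus norvegicus) (a higher number here means a weaker inhibitor, a lower number a stronger inhibitor), compound 1 gives > 100000 nM, which is a limit of the assay rather than a number. Compound 3 `O=c1ccc(CCO)n[nH]1` likewise stops at a limit, giving > 100000 nM in this assay. Compound 2 `O=c1ccc(COCc2ccccc2)nn1Cc1ccccc1` gives 35300 nM in this assay. For the measured compounds named here, the single measured step that touches the hydroxyl of compound 1 is an at least 2.8-fold lower number from compound 1 to compound 2 (0.45 log units; beyond the scatter), and its size is bounded by the limit of > 100000 nM in this assay, at which 2 of the 3 values shown sit. Compound 4 `O=c1ccc(CCCO)nn1Cc1ccccc1` has not yet been measured; it differs from compound 1 by 2-hydroxyethyl in place of hydroxy on a saturated chain carbon bound to an aromatic carbon. Going by the values given here, no measured step covers lengthening the chain while the hydroxyl is kept, and compound 3, which carries a 2-hydroxyethyl chain on the unsubstituted core, sits at the limit. With the hydroxyl retained, at most a modest lowering of the number is expected, and the measurement may again return only a limit. For compound 4 the expected value in this assay is 80000 nM, with a range from 30000 nM to 200000 nM. The expected step is accordingly an at least 1.2-fold lower number from compound 1 to compound 4 (0.09 log units; that floor lies within the scatter).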

Compound 4, half-maximal inhibitory concentration: > 100000 nM
Compound 4 ended at the assay's limit (the forecaster's own chance of this, stated with the estimate: 55%); middle value at least 1.2-fold (0.09 log units) from the limit.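

For the compounds shown here, compound 1 and compound 4 both stop at a limit of the assay, so no step between them can be read: the limit of > 100000 nM in this assay, at which 3 of the 4 values shown sit. The compounds shown leave open whether the number in this assay changes at all from hydroxymethyl to 3-hydroxypropyl on the shared core.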